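Swapping Cyclobutylamino for Methoxy on Compound 1

The source may report more compounds than this note shows. Statements on the series, on what has been measured and on what is new or still open speak of the compounds shown alone.

Measured so far:
Compound 1: `CCCc1cc(NC2CCC2)c2cc(NC(=O)/C=C/c3ccc(C(F)(F)F)cc3)ccc2n1` — 270 nM
Compound 2: `CCCc1cc(N)c2cc(NC(=O)/C=C/c3ccc(C(C)C)cc3)ccc2n1` — 520 nM

Of the compounds shown here, two have been measured in a functional assay on HEK293 cells for activation of melanin-concentrating hormone receptor 1 (Homo sapiens), read by inositol phosphate accumulation; a higher number here means that more compound is needed for the effect, a lower number that less compound is needed. Compound 1 gives 270 nM, and compound 2 gives 520 nM. Compound 1 holds the lower of the two numbers, but its gap to compound 2 lies within the scatter of repeated measurements, so the two cannot be separated on these data. Compound 3, `CCCc1cc(OC)c2cc(NC(=O)/C=C/c3ccc(C(F)(F)F)cc3)ccc2n1`, has not yet been measured. It differs from compound 1 in one place: methoxy in place of cyclobutylamino on an aromatic carbon. Within the data shown here, no pair of measured compounds shows this same change, and compound 2 differs from compound 1 in more than one place, so the size of the step cannot be read from the numbers at hand. The step of a 3.0-fold higher number from compound 1 to compound 3 (0.47 log units; beyond the scatter) is expected to go toward a higher number, somewhat beyond the scatter. Compound 3 is estimated at 800 nM, with a range from 250 nM to 2500 nM.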

Compound 3, half-maximal effective concentration: 360 nM
For compound 3 the middle estimate is 2.2-fold (0.35 log units) above the measured one, and the stated range covers the measured number.
By their numbers in this assay, from the lowest: compounds 1, 3 and 2 (each within the scatter of the next).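

In this assay, methoxy in place of cyclobutylamino, on the aromatic carbon opposite the ring nitrogen, gives a 1.3-fold higher number from compound 1 to compound 3 (0.12 log units; within the scatter), so the two compounds cannot be told apart on this read-out. At this position, then, the cyclobutylamino group, with its four-membered ring and its hydrogen-bond donor, can be exchanged for methoxy, with no ring and 0 hydrogen-bond donors, without a readable shift in the number. No accompanying measurement bears on this result.

Going by these compounds, whether a longer alkoxy chain, a hydroxyl or a dimethylamino group at this position would also stay within the scatter remains open. The steps to compound 2 cannot be read, since it differs from compound 1 and compound 3 in more than one place, so its amino group offers no separate comparison.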